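A few compounds are considered here, and "the series" means these few. Any claim that something is new, unique, unknown or untested is made for them only; others in the source may bear on it.

Measured in an ADME assay on MT4 cells (Homo sapiens) for cytotoxicity, read by MTT assay, with a stated time of 4 days; a lower number here means that less compound is tolerated, a higher number that more compound is tolerated:

- compound 1, `COc1ccccc1-c1oc2ccc(NC(C)=O)cc2c(=O)c1OC`: 154000 nM
- compound 2, `COc1cccc(-c2oc3ccc(NC(C)=O)cc3c(=O)c2OC)c1`: 369000 nM
- compound 3, `COc1ccc(-c2oc3ccc(NC(C)=O)cc3c(=O)c2OC)cc1`: 369000 nM

Compound 1 has the lowest number of the three, and it is the only one set apart from the others. The measured steps are a 2.4-fold higher number from compound 1 to compound 2 (0.38 log units; beyond the scatter) and a 2.4-fold higher number from compound 1 to compound 3 (0.38 log units; beyond the scatter). Between the other two, the step is no change at the digits printed from compound 2 to compound 3 (within the scatter).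

The next compound is compound 4, `COc1ccccc1-c1oc2ccc(N)cc2c(=O)c1OC`, which has not yet been measured in this assay. It differs from compound 1 at a single place: hydrogen in place of acetyl on a nitrogen on an aromatic ring, or acetamido to amino. The counted difference is hydrogen in place of acetyl on a nitrogen on an aromatic ring.

Within the data shown here, none of the measured steps touches this place. All three concern the methoxyphenyl group, so they show only how far this small set has moved so far and give no direction for the loss of the acetyl. The largest of them, a 2.4-fold higher number from compound 1 to compound 2 (0.38 log units; beyond the scatter), is modest, and a step of about that size or smaller is a reasonable expectation. With no evidence on direction, the estimate stays close to compound 1, leaning only slightly lower, and keeps a wide range on both sides.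

The expected change is a 1.4-fold lower number from compound 1 to compound 4 (0.15 log units; within the scatter). For compound 4 the estimated value is 110000 nM, with an expected range from 35000 nM to 320000 nM.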

Compound 4, half-maximal cytotoxic concentration: 229000 nM
Beside the measured number, compound 4's estimate is 2.1-fold (0.32 log units) below it; measured number inside the range.
By their numbers in this assay, from the lowest: compounds 1, 4, 2 and 3 (each within the scatter of the next, the first and the last beyond it).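

Among these compounds, the exchange of acetamido for amino is the first change in this set at the nitrogen on an aromatic ring, and in this assay it gives a 1.5-fold higher number from compound 1 to compound 4 (0.17 log units; within the scatter). The earlier steps shown here all concerned the methoxyphenyl group, whereas this one shows that, with 2-methoxyphenyl held fixed, the acetyl can be replaced by hydrogen without a step beyond the scatter, so on this single pair the acetyl makes no clear difference to the number. Nothing available bears on why the number behaves this way at this position.

The compounds shown leave open whether the same exchange would give a step of similar size with 3-methoxyphenyl or 4-methoxyphenyl in place of 2-methoxyphenyl, since one pair cannot show whether the result carries over to the rest of the set. They also leave open how this assay would read with a longer acyl chain such as butanoyl, or with a methyl group or a methanesulfonyl group, on the same nitrogen.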